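The source may report more compounds than this note shows. Statements on the series, on what has been measured and on what is new or still open speak of the compounds shown alone.

Measured compounds and their values:

- Compound 1, `COc1cc(Br)cc(/C=C/C(=O)c2ccc(Br)cc2)c1O`: 48.3%
- Compound 2, `COc1cccc(C(=O)CC2C(C#N)=C(N)Oc3c(OC)cc(Br)cc32)c1`: 33.9%
- Compound 3, `Cc1ccc(C(=O)CC2C(C#N)=C(N)Oc3ccc(Cl)cc32)cc1`: 49%

Three compounds have been run in a functional assay on MCF7 cells (Homo sapiens) for antiproliferative activity, read by sulforhodamine B assay, with a stated time of 72 h, tested at 30 uM; on this read-out lower numbers stand for a stronger effect and higher numbers for a weaker effect at the one concentration tested. Compound 1 has the structure `COc1cc(Br)cc(/C=C/C(=O)c2ccc(Br)cc2)c1O` and gives 48.3%. Compound 2, `COc1cccc(C(=O)CC2C(C#N)=C(N)Oc3c(OC)cc(Br)cc32)c1`, gives 33.9%. Compound 3, `Cc1ccc(C(=O)CC2C(C#N)=C(N)Oc3ccc(Cl)cc32)cc1`, gives 49%, the highest of the three numbers, which in this read-out means the weakest effect at the concentration tested. The nearest to it is compound 1, whose number lies within the usual scatter of compound 3, so the two cannot be told apart. Compound 2 sits lower than compound 3 by more than the scatter, so compound 2 shows the stronger effect of that pair.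

Compound 4, `Cc1ccc(C(=O)CC2C(C#N)=C(N)Oc3ccc(Br)cc32)cc1`, has not yet been measured. It differs from compound 3 in one place: bromo in place of chloro on an aromatic carbon.

Within the data shown here, no pair of the measured compounds differs in only this one place, so there is no direct comparison to lean on. An exchange of one halogen for another at the same position is usually a small matter, so the step of a number 2 percentage points lower from compound 3 to compound 4 (within the scatter) is expected to stay within the scatter, in no particular direction. Compound 4 is therefore estimated at 47%, with a range from 30% to 64% in this assay.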

Compound 4, a percentage reported as activity, at one concentration (the size of the read-out at that concentration, not a potency): 32.3%
Estimate against measurement, compound 4: 14.7 percentage points above; the range from low to high includes it.
By their numbers in this assay, from the lowest: compounds 4 and 2 (each within the scatter of the next); then compounds 1 and 3 (each within the scatter of the next).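

Bromo in place of chloro at this position, on an aromatic carbon of the fused system of two rings, is not a silent exchange: in this assay it gives a number 16.7 percentage points lower from compound 3 to compound 4 (beyond the scatter). Among these compounds, no two of the earlier compounds differed in one place only, so they could say nothing about any single change, and this pair is the first to show that the read-out responds to which halogen sits on this carbon. Nothing shown here explains why these two halogens differ.

The compounds shown leave open what fluoro, iodo, a methoxy group or a plain hydrogen on this carbon would give, and so whether the read-out follows the size of the halogen series or bromo is a special case. They also leave open whether the same exchange would give a step of similar size with a different group on the other aromatic ring, since a single pair tested at one concentration cannot show how far this holds.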